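This account rests on a few compounds, and the source may have more. Where it says the series, first, only, none or still open, it means among the compounds named here.

Working notes on the series. In a functional assay on HepG2 cells (Homo sapiens) for cytotoxicity, read by MTT assay, with a stated time of 24 h (on this read-out higher numbers stand for weaker inhibition and lower numbers for stronger inhibition), compound 1 `CN1C/C(=C\c2cccnc2)C(=O)/C(=C/c2ccccc2F)C1` gives 4810 nM, compound 2 `O=C1/C(=C/c2cccnc2)CN(S(=O)(=O)c2ccccc2)C/C1=C\c1ccccc1F` gives 8210 nM, and compound 3 `O=C1/C(=C/c2cccnc2)CN(S(=O)(=O)c2ccccc2)C/C1=C\c1ccccc1C(F)(F)F` gives 5370 nM. Compound 3 is not separated from the other two, since its value lies within the usual scatter of both.

Compound 4 `O=C1/C(=C/c2cccnc2)CN(S(=O)(=O)c2ccc(Br)cc2)C/C1=C\c1ccccc1C(F)(F)F` differs from compound 3 by bromo in place of hydrogen on an aromatic carbon. This is bromo in place of hydrogen on an aromatic carbon, para to a large group, which turns phenylsulfonyl into (4-bromophenyl)sulfonyl.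

Going by the values given here, two measured steps bear on this only indirectly. The first is a 1.7-fold higher number from compound 1 to compound 2 (0.23 log units; within the scatter), with phenylsulfonyl in place of methyl on an amine nitrogen in a ring. The second is a 1.5-fold lower number from compound 2 to compound 3 (0.18 log units; within the scatter), with trifluoromethyl in place of fluoro on an aromatic carbon. Both lie within the scatter. Neither alters the phenylsulfonyl group once it is present, so the series holds no direct measurement of this change. With only these two small steps as a guide, no shift beyond the scatter is expected in this assay. The estimate amounts to a 1.2-fold lower number from compound 3 to compound 4 (0.08 log units; within the scatter), an expected step within the scatter. Compound 4 is expected at 4500 nM, with an estimated range of 2200 nM to 9000 nM.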

Compound 4, half-maximal inhibitory concentration: 2730 nM
Beside the measured number, compound 4's estimate is 1.6-fold (0.22 log units) above it, within the range that was stated.
By their numbers in this assay, from the lowest: compounds 4, 1, 3 and 2 (each within the scatter of the next, the first and the last beyond it).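

In this assay, going by these compounds alone, the series now holds a 2.0-fold lower number from compound 3 to compound 4 (0.29 log units; within the scatter), the first reading of a change made on the phenyl ring of the phenylsulfonyl group itself rather than on the group's attachment to the shared core or on the other aromatic ring. Bromo in place of hydrogen on an aromatic carbon, para to a large group, turns phenylsulfonyl into (4-bromophenyl)sulfonyl and leaves compound 4 within the usual scatter of compound 3, so this position accepts bromo without a separation that can be read in this cytotoxicity measurement. No supporting measurement bears on this result, and the series gives no explanation of the step.

The compounds shown leave open how a chloro group, a methoxy group, an amine or a carboxylic acid would read at this same place in this assay. They also leave open whether (4-bromophenyl)sulfonyl would read the same with fluoro in place of trifluoromethyl on the other aromatic ring, as the reading for this change rests on a single pair of compounds.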